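Swapping Chloro for Trifluoromethyl on the Amide Ring

A few compounds are considered here, and "the series" means these few. Any claim that something is new, unique, unknown or untested is made for them only; others in the source may bear on it.

Of the compounds shown here, three built on one shared core have been measured in an assay on LtK cells with ATP-sensitive inward rectifier potassium channel 11 (Homo sapiens) as the target; a higher number here means that more compound is needed for the effect, a lower number that less compound is needed. Compound 1 `O=C(Nc1c(C(O)(C(F)(F)F)C(F)(F)F)ccc2ccccc12)C1CCC1` gives 45 nM in this assay. Compound 2 `O=C(Nc1c(C(O)(C(F)(F)F)C(F)(F)F)ccc2ccccc12)c1ccccc1`, with phenyl in place of cyclobutyl on the carbonyl carbon, gives 44 nM; the two values sit a 1.0-fold lower number from compound 1 to compound 2 (0.01 log units; within the scatter) apart. Compound 3 `O=C(Nc1c(C(O)(C(F)(F)F)C(F)(F)F)ccc2ccccc12)c1cccc(Cl)c1` gives 98 nM, the highest of the three numbers, set apart by a 2.2-fold higher number from compound 2 to compound 3 (0.35 log units; beyond the scatter) and by a 2.2-fold higher number from compound 1 to compound 3 (0.34 log units; beyond the scatter).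

Compound 4 `O=C(Nc1c(C(O)(C(F)(F)F)C(F)(F)F)ccc2ccccc12)c1cccc(C(F)(F)F)c1` is the next step: trifluoromethyl in place of chloro on an aromatic carbon. Among the measured compounds shown here, no measured pair shows this exact swap. For the measured compounds named here, the only step that touches the same aromatic carbon replaced hydrogen with chloro and gave a 2.2-fold higher number from compound 2 to compound 3 (0.35 log units; beyond the scatter); it shows that a group at this carbon can move the number modestly, but it does not say what a second, different group will do. For compound 4 a modest rise in this assay is therefore expected, a 1.4-fold higher number from compound 3 to compound 4 (0.15 log units; within the scatter), though a result within the scatter of compound 3 would not surprise. Compound 4 is estimated at 140 nM in this assay, with a likely range from 55 nM to 360 nM.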

Compound 4, half-maximal effective concentration: 84 nM
The estimate for compound 4 lay 1.7-fold (0.22 log units) above the measured number; the measured number falls inside the stated range.
By their numbers in this assay, from the lowest: compounds 2, 1, 4 and 3 (each within the scatter of the next, the first and the last beyond it).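

In this assay the swap of chloro for trifluoromethyl on this aromatic carbon, a group of 4 heavy atoms in place of one of 1, gives a 1.2-fold lower number from compound 3 to compound 4 (0.07 log units; within the scatter) and so cannot be read as a change at all. Measured against the plain phenyl ring, trifluoromethyl gives a 1.9-fold higher number from compound 2 to compound 4 (0.28 log units; within the scatter) while chloro gave a 2.2-fold higher number from compound 2 to compound 3 (0.35 log units; beyond the scatter) earlier, so only the chloro step clears the scatter, yet the two substituted compounds cannot be told apart from each other. Compound 4 also stays close to the compound with cyclobutyl on the carbonyl carbon, with a 1.9-fold higher number from compound 1 to compound 4 (0.27 log units; within the scatter) as the step, which means that this larger group at this position brings no clear difference from either simpler compound in this series.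

The compounds shown leave open what a group of a different kind, such as an amine, a carboxylic acid or a methoxy group, would do on this same carbon, and whether chloro or trifluoromethyl would behave alike on the other carbons of this ring. Nothing measured here on these compounds offers an explanation for these numbers.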